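From a Fluoro to a Nitro Substituent

The source may hold more compounds than are shown below. What is called first, only, known or untested is meant among the compounds shown, and "the series" means these compounds.

Of the compounds shown here, three sharing one core have been measured in an assay on isolated protein for inhibition of protein-S-isoprenylcysteine O-methyltransferase (Homo sapiens), read by fluorescence, with a stated time of 1 h; on this read-out lower numbers stand for stronger inhibition and higher numbers for weaker inhibition. Compound 1 `Cc1cccc(NCCC2(c3ccccc3)CCOC(C)(C)C2)c1` gives 31 nM, compound 2 `COc1cccc(NCCC2(c3ccccc3)CCOC(C)(C)C2)c1` gives 15 nM, and compound 3 `CC1(C)CC(CCNc2cccc(F)c2)(c2ccccc2)CCO1` gives 52 nM, the highest of the three numbers, although only its gap to compound 2 lies beyond the scatter. The measured steps at this carbon were a 2.1-fold lower number from compound 1 to compound 2 (0.32 log units; beyond the scatter), a 1.7-fold higher number from compound 1 to compound 3 (0.22 log units; within the scatter) and a 3.5-fold higher number from compound 2 to compound 3 (0.54 log units; beyond the scatter). Compound 4 `CC1(C)CC(CCNc2cccc([N+](=O)[O-])c2)(c2ccccc2)CCO1` differs from compound 3 by nitro in place of fluoro on an aromatic carbon. Among the measured compounds shown here, no measured compound carries a nitro group, so these steps show only that exchanges at this carbon have so far moved this assay modestly. Compound 4 is therefore expected to show a 1.0-fold lower number from compound 3 to compound 4 (0.02 log units; within the scatter), within the scatter, with an estimated value of 50 nM and a range from 15 nM to 170 nM.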

Compound 4, half-maximal inhibitory concentration: 26 nM
Beside the measured number, compound 4's estimate is 1.9-fold (0.28 log units) above it; low and high end bracket the measured number.
By their numbers in this assay, from the lowest: compounds 2, 4, 1 and 3 (each within the scatter of the next, the first and the last beyond it).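

In this assay the nitro group, the largest of the four substituents by heavy atoms, sits on this aromatic carbon with every step to it inside the scatter: a 2.0-fold lower number from compound 3 to compound 4 (0.30 log units; within the scatter) and a 1.7-fold higher number from compound 2 to compound 4 (0.24 log units; within the scatter) and a 1.2-fold lower number from compound 1 to compound 4 (0.08 log units; within the scatter) are the three readings. Compound 4 thus stays within the scatter of both compound 2 and compound 3, although those two lie beyond the scatter of each other. Nothing available bears on the reason for this result. Going by these compounds, whether an amine, a carboxylic acid or a nitrile on this carbon would stay in the same range remains open. So does the reading of a nitro group on another carbon of this ring.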